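Carbamate in Place of Acyl Azide on a Chlorinated Core

The source may report more compounds than this note shows. Statements on the series, on what has been measured and on what is new or still open speak of the compounds shown alone.

Measured compounds:
compound 1 `Cc1c(C(=O)N=[N+]=[N-])[n+]([O-])c2cc(Cl)ccc2[n+]1[O-]` — 98%
compound 2 `COc1ccc2c(c1)[n+]([O-])c(C(=O)N=[N+]=[N-])c(C)[n+]2[O-]` — 83.9%
compound 3 `COc1ccc(NC(=O)Nc2c(C)[n+]([O-])c3ccc(Cl)cc3[n+]2[O-])cc1` — 83%

In a functional assay on Ehrlich cells (Mus musculus) for cytotoxicity, read by trypan blue exclusion, with a stated time of 2 h, tested at 10 ug/mL (a lower number here means a stronger effect, a higher number a weaker effect of the compound at the concentration tested), compound 1 gives 98%, the highest of the three numbers, with both other compounds lying beyond the scatter below it. Within the data shown here, the one single-point step recorded, a number 14.1 percentage points lower from compound 1 to compound 2 (beyond the scatter), concerns a methoxy in place of chloro on an aromatic carbon and does not touch the position changed here. Among the measured compounds shown here, compound 3, which carries a urea-type group at the corresponding place, gives 83%; no single step links it to compound 1, so only the two values themselves can be compared.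

Compound 4 `Cc1c(NC(=O)OC(C)C)[n+]([O-])c2cc(Cl)ccc2[n+]1[O-]` differs from compound 1 by a group of 7 heavy atoms (4 carbon, 1 nitrogen, 2 oxygen; no ring) in place of a group of 5 heavy atoms (1 carbon, 3 nitrogen, 1 oxygen; no ring), on an aromatic carbon. For the measured compounds named here, since the only step that bears on a change at an aromatic carbon was modest and lowered the number, and compound 3 with a nitrogen-linked group at the changed position also reads lower, a small decrease is expected, with a number 13 percentage points lower from compound 1 to compound 4 (beyond the scatter) as the estimated step. Compound 4 is estimated to give 85%, expected between 70% and 98%.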

Compound 4, a percentage reported as activity, at one concentration (the size of the read-out at that concentration, not a potency): 98.3%
Compound 4: middle estimate off by 13.3 percentage points, on the low side, and the stated range ends below it.
By their numbers in this assay, from the lowest: compounds 3 and 2 (each within the scatter of the next); then compounds 1 and 4 (each within the scatter of the next).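

In this assay, putting (isopropoxycarbonyl)amino in place of the acyl azide on the aromatic carbon next to the ring nitrogen gives a number 0.3 percentage points higher from compound 1 to compound 4 (within the scatter) and so leaves the read-out of the chlorinated core unchanged, which the earlier step at another place on the core could not show. With a nitrogen-linked group at this same place, compound 3 gives 83% and compound 4 gives 98.3%, so a nitrogen link here does not by itself fix the value. Nothing at hand explains the result.

From the compounds shown here alone, whether a free amine or a carboxylic acid at this position would read like compound 4 stays open, as does the effect of a longer chain in place of the isopropyl group. Also open, going by these compounds, is how the (isopropoxycarbonyl)amino group behaves on the methoxy core of compound 2.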